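The source may hold more compounds than are shown below. What is called first, only, known or untested is meant among the compounds shown, and "the series" means these compounds.

Measured in a functional assay on 4T1 cells (Mus musculus) for cytotoxicity, read by MTT assay, with a stated time of 24 h; a higher number here means a weaker inhibitor, a lower number a stronger inhibitor:
- Compound 1 `O=C1/C(=C/c2ccccc2F)CN(Cc2cn(Cc3ccccc3F)nn2)C/C1=C\c1ccccc1F`: 6500 nM
- Compound 2 `O=C1/C(=C/c2ccccc2F)CN(C(=S)SCc2cn(Cc3ccccc3F)nn2)C/C1=C\c1ccccc1F`: 30700 nM
- Compound 3 `O=C1/C(=C/c2ccccc2F)CN(Cc2cn(Cc3ccccc3Cl)nn2)C/C1=C\c1ccccc1F`: 5300 nM

Compound 2 has the highest number of the three, and so is the weakest inhibitor here. Compound 4 `O=C1/C(=C/c2ccccc2F)CN(C(=S)SCc2cn(Cc3cccc(Cl)c3)nn2)C/C1=C\c1ccccc1F` is not yet measured. It differs from compound 2 by 3-chlorophenyl in place of 2-fluorophenyl on a saturated chain carbon bound to an aromatic nitrogen. Within the data shown here, the only measured step that bears on this is a 1.2-fold lower number from compound 1 to compound 3 (0.09 log units; within the scatter). It swaps chloro for fluoro, but without the other features of this change, so it is only a loose guide. No step beyond the scatter is therefore expected in this assay. The estimated step is a 1.2-fold lower number from compound 2 to compound 4 (0.07 log units; within the scatter). For compound 4 the expected value is 26000 nM, with an estimated range of 11000 nM to 60000 nM.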

Compound 4, half-maximal inhibitory concentration: > 100000 nM
Compound 4 ended at the assay's limit (the forecaster's own chance of this, stated with the estimate: 5%); middle value at least 3.8-fold (0.58 log units) away from the limit.
By their numbers in this assay, from the lowest: compounds 3 and 1 (each within the scatter of the next); then compound 2. At a limit, above all of these: compound 4.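

In this assay, the ring on a saturated chain carbon bound to an aromatic nitrogen turns out to matter: going from 2-fluorobenzyl to 3-chlorobenzyl gives an at least 3.2-fold higher number from compound 2 to compound 4 (0.51 log units; beyond the scatter). The earlier swap of chloro for fluoro, made with a different link to the shared core, gave only a 1.2-fold lower number from compound 1 to compound 3 (0.09 log units; within the scatter). The result for compound 4 is a limit, not a number: the limit of > 100000 nM in this assay, at which 1 of the 4 values shown sits.

Compound 4 changes both the halogen and its place on the ring, and the compounds shown do not separate the two. From the compounds shown here alone, how a methoxy group or an amine on that ring would read also stays open.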